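The source may hold more compounds than are shown below. What is called first, only, known or untested is meant among the compounds shown, and "the series" means these compounds.

Working notes on the urea series.

Three compounds have numbers in an assay on microsomes from intestine for inhibition of acyl-CoA:cholesterol acyltransferase (Oryctolagus cuniculus); a higher number here means a weaker inhibitor, a lower number a stronger inhibitor. Compound 1 `Cc1cc(C)c(NC(=O)N(Cc2ccc(N3CCN(C)CC3)cc2)C2CCCCCC2)c(C)c1` gives 57 nM. Among the measured compounds shown here, compound 2 `Cc1cc(C)c(NC(=O)N(Cc2ccc(-c3ccsc3)cc2)C2CCCCCC2)c(C)c1` gives 19 nM, and the step from compound 1 to compound 2, a 3.0-fold lower number from compound 1 to compound 2 (0.48 log units; beyond the scatter), is the only single-place change measured so far; it sits on the aromatic carbon of the benzyl group, not on the urea nitrogen. Compound 3 `O=C(Nc1c(F)cc(F)cc1F)N(Cc1ccc(-c2ccccn2)cc1)C1CCCCCC1` gives 25 nM; it holds the second highest of the three numbers, within the scatter of compound 2 and beyond the scatter of compound 1.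

Compound 4 `Cc1cc(C)c(NC(=O)N(Cc2ccc(-c3ccccn3)cc2)C2CCCCCC2)c(C)c1` is not yet measured. It differs from compound 3 in one place: 2,4,6-trimethylphenyl in place of 2,4,6-trifluorophenyl on an amide-type nitrogen. For the measured compounds named here, no measured pair in this assay differs only at that urea nitrogen; compound 1 and compound 2 both already carry the trimethylphenyl group, and the step from compound 1 to compound 2 concerns a different position, so it does not bear on this change. Compound 2, which shares the trimethylphenyl urea with compound 4, and compound 3, which shares the pyridinyl benzyl group, lie within the scatter of each other. On that basis no step beyond the scatter is expected for this change, a 1.3-fold lower number from compound 3 to compound 4 (0.10 log units; within the scatter). Compound 4 is therefore estimated at 20 nM, with a range from 8 nM to 50 nM.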

Compound 4, half-maximal inhibitory concentration: 33 nM
Beside the measured number, compound 4's estimate is 1.7-fold (0.22 log units) below it; measured number inside the range.
By their numbers in this assay, from the lowest: compounds 2, 3, 4 and 1 (each within the scatter of the next, the first and the last beyond it).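

In this assay the amide-type nitrogen now has its first measured single-place pair: with the pyridin-2-yl benzyl group held constant, 2,4,6-trimethylphenyl in place of 2,4,6-trifluorophenyl leaves the two compounds indistinguishable (a 1.3-fold higher number from compound 3 to compound 4 (0.12 log units; within the scatter)). On the aromatic carbon of the benzyl group, pyridin-2-yl cannot be separated from thiophen-3-yl (a 1.7-fold higher number from compound 2 to compound 4 (0.24 log units; within the scatter)) or from 4-methylpiperazin-1-yl (a 1.7-fold lower number from compound 1 to compound 4 (0.24 log units; within the scatter)), although the step between those two groups lies beyond the scatter (a 3.0-fold lower number from compound 1 to compound 2 (0.48 log units; beyond the scatter)). No measurement shown offers an explanation for any of these results.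

Among the compounds shown here, whether 2,4,6-trimethylphenyl and 2,4,6-trifluorophenyl also match when thiophen-3-yl or 4-methylpiperazin-1-yl sits on the benzyl group remains open, as the only pair at this nitrogen carries pyridin-2-yl. Also open, from the compounds shown here alone, is whether a phenyl group with no substituents, or one carrying methoxy groups or chlorine atoms, would separate from these two groups at the same nitrogen.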